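The compounds below may be only part of what the source reports. "The series", "measured", "known", "first", "only" and "open" are said of these compounds alone.

Measured so far in an assay on HEK293 cells for binding affinity to Free fatty acid receptor 1 (Homo sapiens), read by scintillation counting and radioligand binding, with a stated time of 1 h; a lower number here means a stronger inhibitor, a higher number a weaker inhibitor:
Compound 1 `Cc1ccccc1Cc1ccc(N2CCC[C@H]2CC(=O)O)cc1` gives 1300 nM
Compound 2 `Cc1ccccc1Cc1ccc(N2CC[C@H](C)[C@H]2CC(=O)O)cc1` gives 310 nM
Compound 3 `Cc1ccccc1Cc1ccc(N2C[C@@H](c3ccccc3)C[C@H]2CC(=O)O)cc1` reaches only a limit of the assay, > 25000 nM

Compound 1 holds the highest of the two numbers shown; compound 2 sits a 4.2-fold lower number from compound 1 to compound 2 (0.62 log units; beyond the scatter) away, and the limit of compound 3 lies an at least 19-fold higher number from compound 1 to compound 3 (1.28 log units; beyond the scatter) further up (the limit of > 25000 nM in this assay, at which 1 of the 3 values shown sits). Compound 4 `COc1ccc(F)c(-c2ccc(Cc3ccc(N4CCC[C@H]4CC(=O)O)cc3)c(C)c2)c1` differs from compound 1 by 2-fluoro-5-methoxyphenyl in place of hydrogen on an aromatic carbon. Neither measured step touches this position: both changed a saturated ring carbon, one modestly, one largely. They therefore give no direct guide to the new group on the aromatic ring. A step of moderate size toward a lower number is nonetheless expected, a 6.5-fold lower number from compound 1 to compound 4 (0.81 log units; beyond the scatter), with wide uncertainty. Compound 4 is estimated at 200 nM, between 30 nM and 1500 nM.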

Compound 4, inhibition constant: 310 nM
Estimate against measurement, compound 4: 1.6-fold (0.19 log units) below; the range from low to high includes it.
By their numbers in this assay, from the lowest: compounds 2 and 4 (each within the scatter of the next); then compound 1. At a limit, above all of these: compound 3.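

Placing 2-fluoro-5-methoxyphenyl on this aromatic carbon gives a 4.2-fold lower number from compound 1 to compound 4 (0.62 log units; beyond the scatter), the first sign that this position accepts a large added ring and still allows binding. The change also shows that the aromatic ring, and not only the saturated ring, offers a place where the number can fall. No measurement shown here accounts for this step.

The compounds shown leave open which part of the group carries the step: an unsubstituted phenyl, or a ring with only the fluorine or only the methoxy, would separate them. On these data alone, how an amine or a carboxylic acid on the added ring would fare also remains open.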